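This account rests on a few compounds, and the source may have more. Where it says the series, first, only, none or still open, it means among the compounds named here.

Measured in a functional assay on MCF7 cells (Homo sapiens) for cytotoxicity, read by WST assay, with a stated time of 72 h; a higher number here means a weaker inhibitor, a lower number a stronger inhibitor:
- compound 1 `Cc1ccc(C2(c3ccc(O)cc3)C(=O)Nc3c2ccc(F)c3F)cc1`: 1.7 nM
- compound 2 `O=C1Nc2c(ccc(F)c2F)C1(c1ccc(O)cc1)c1ccc(F)c(F)c1`: 7.8 nM

Of these two numbers, compound 2 has the higher, 7.8 nM, making it the weaker inhibitor. Compound 3 `CCCC1(c2ccc(O)cc2)C(=O)Nc2c1ccc(F)c2F` carries propyl in place of 3,4-difluorophenyl on a saturated ring carbon. Going by the values given here, only one measured step bears on this change: a 4.6-fold higher number from compound 1 to compound 2 (0.66 log units; beyond the scatter). Among the compounds with values here, that step exchanged one substituted phenyl group for another, while no measured compound shows the loss of that ring, so it is only a loose guide. A step of similar size is therefore expected in this assay, toward a higher number: a 3.2-fold higher number from compound 2 to compound 3 (0.51 log units; beyond the scatter). For compound 3 the estimated value is 25 nM, with an expected range of 4 nM to 150 nM.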

Compound 3, half-maximal inhibitory concentration: > 1000 nM
Compound 3: no number, only a limit; the forecaster's own chance of this, stated with the estimate: 3%; at least 40-fold (1.60 log units) between middle value and limit.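

In this assay compound 3 gives no number, only a limit: the limit of > 1000 nM in this assay, at which 1 of the 3 values shown sits. Propyl on the saturated ring carbon gives an at least 120-fold higher number from compound 2 to compound 3 (2.10 log units; beyond the scatter) and an at least 580-fold higher number from compound 1 to compound 3 (2.76 log units; beyond the scatter), both large, whereas swapping one substituted phenyl for the other was a modest change. Among these compounds, then, the two with a phenyl ring at this position keep low numbers, and the one with propyl does not.

As far as these compounds go, whether an aromatic ring is needed here, or any ring would do, remains open. A cyclohexyl group or a longer chain at this carbon would help to separate these possibilities.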